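A Methylsulfonyl in Place of the Sulfamoyl Group

A few compounds are considered here, and "the series" means these few. Any claim that something is new, unique, unknown or untested is made for them only; others in the source may bear on it.

Measured compounds:
compound 1, `COc1ccc(S(N)(=O)=O)cc1C(=O)Nc1cccc(-c2nncn2C(C)C)n1`, 0%
compound 2, `COc1cc(C)c(S(N)(=O)=O)cc1C(=O)Nc1cccc(-c2nncn2C(C)C)n1`, 0%

Both measured compounds were tested in an assay for inhibition of casein kinase I isoform alpha (Homo sapiens), tested at 1 uM; a higher number here means more inhibition at the concentration tested (going by the name of the read-out), a lower number less inhibition. Compound 1 gives 0% there, and compound 2 gives 0%. The one measured step, no change at the digits printed from compound 1 to compound 2 (within the scatter), is within the scatter, so compound 1 stands level with compound 2 at the digits shown.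

Compound 3, `COc1ccc(S(C)(=O)=O)cc1C(=O)Nc1cccc(-c2nncn2C(C)C)n1`, has not been measured. It differs from compound 1 in one place: methyl in place of amino on a sulfonyl sulfur, the same difference read one bond further out being sulfamoyl to methylsulfonyl. Within the data shown here, no measured step touches this sulfonyl sulfur; the only step available, no change at the digits printed from compound 1 to compound 2 (within the scatter), concerns an aromatic carbon and showed nothing beyond the scatter. Among the measured compounds shown here, with compound 1 at the floor of the read-out and no change seen from its one neighbour, the step to compound 3 is expected to be a number 2 percentage points higher from compound 1 to compound 3 (within the scatter), nothing beyond the scatter in either direction. Compound 3 is therefore estimated to give 2%, within -8% to 12%.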

Compound 3, a percentage reported as inhibition, at one concentration (the size of the read-out at that concentration, not a potency): -3%
For compound 3 the middle estimate is 5 percentage points above the measured one; low and high end bracket the measured number.
By their numbers in this assay, from the lowest: compounds 3, 1 and 2 (each within the scatter of the next).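

In this assay, the sulfonyl sulfur now has a measured step of its own: methyl in place of amino gives a number 3 percentage points lower from compound 1 to compound 3 (within the scatter). Compound 1 gives 0%, so a loss could hardly register in this read-out, and what the step adds is that this change on the sulfonyl sulfur brings no gain beyond the scatter at the concentration tested, even though the hydrogen-bond donor of the amino group leaves. Nothing available explains this result.

Going by these compounds, whether an ethyl chain or a dimethylamino group on the sulfonyl sulfur would give a number beyond the scatter remains open. Also open, on these data alone, is whether amino and methyl would still read alike on a core that shows clear inhibition in this assay.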